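Dechlorination on the fused core of compound 2

The source may report more compounds than this note shows. Statements on the series, on what has been measured and on what is new or still open speak of the compounds shown alone.

Two compounds in the series have numbers in a functional assay on MDA-MB-435 cells (Homo sapiens) for cytotoxicity, read by sulforhodamine B assay, with a stated time of 48 h; a higher number here means a weaker inhibitor of growth, a lower number a stronger inhibitor of growth. Compound 1 `Nc1nc(Cl)c2ncn(Cc3ccccc3CCl)c2n1` carries an amino group and a chloro group on its fused core and gives 6030 nM in this assay. Compound 2 `ClCc1cccc(Cn2cnc3nc(Cl)nc(Cl)c32)c1` carries two chloro groups on the same core, and in this assay compound 2 gives 1470 nM, the lower of the two numbers; the gap to compound 1 lies beyond the usual scatter. The two compounds differ in more than one place, so no single change accounts for that gap.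

Compound 3 `ClCc1cccc(Cn2cnc3ncnc(Cl)c32)c1` follows from compound 2 by one change: hydrogen in place of chloro on an aromatic carbon. Removing a chloro group from the core leaves the rest of compound 2 intact, including the chloromethyl benzyl group.

For the measured compounds named here, no measured pair shows this change on its own, so the direction is open. A modest step is expected, most likely toward a higher number, giving an estimated 1.7-fold higher number from compound 2 to compound 3 (0.23 log units; within the scatter) in this assay. For compound 3 the expected value in this assay is 2500 nM, with a range of 900 nM to 7000 nM.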

Compound 3, concentration for 50% growth inhibition: 3460 nM
Estimate against measurement, compound 3: 1.4-fold (0.14 log units) below; measured number inside the range.
By their numbers in this assay, from the lowest: compound 2; then compounds 3 and 1 (each within the scatter of the next).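

In this assay, the chloro group between two ring nitrogen atoms of the shared core now has a direct reading, with a 2.4-fold higher number from compound 2 to compound 3 (0.37 log units; beyond the scatter) while the chloromethyl benzyl group and the other chloro group stay the same. Compound 1 and compound 2 differ in more than one place and could not isolate any single site, whereas this pair ties a modest loss of growth inhibition to this one aromatic carbon, with chloro there giving the stronger inhibitor of growth and hydrogen the weaker. The compounds shown contain no measurement that explains why this position responds to the change.

On these data alone, it remains open whether chloro is distinctive at this carbon or whether another small group, such as fluoro or a methoxy group, would give a number closer to that of compound 2 or to that of compound 3. As far as these compounds go, it also remains open whether the same change gives a step of similar size and direction when the chloromethyl group sits on the benzyl ring as it does in compound 1.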